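Notes on compound 3: isobutyl to sec-butyl

A few compounds are considered here, and "the series" means these few. Any claim that something is new, unique, unknown or untested is made for them only; others in the source may bear on it.

Measured in a functional assay on HeLa cells (Homo sapiens) for antiproliferative activity, read by MTT assay, with a stated time of 48 h; on this read-out higher numbers stand for weaker inhibition and lower numbers for stronger inhibition:
- compound 1 `COC(=O)[C@H](C)NC(=O)c1ccc(Oc2nc3ccccc3nc2C)cc1` gives 32200 nM
- compound 2 `COC(=O)[C@H](CC(C)C)NC(=O)c1ccc(Oc2nc3ccccc3nc2C)cc1` gives 21600 nM
- compound 3 `Cc1nc2ccccc2nc1Oc1ccc(C(=O)N[C@@H](CC(C)C)C(=O)O)cc1` gives 17300 nM

Compound 3, at 17300 nM, cannot be separated from the other two. The series shows a 1.2-fold lower number from compound 2 to compound 3 (0.10 log units; within the scatter) and a 1.9-fold lower number from compound 1 to compound 3 (0.27 log units; within the scatter), so all three stand level on these numbers.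

Compound 4 `CC[C@@H](C)[C@H](NC(=O)c1ccc(Oc2nc3ccccc3nc2C)cc1)C(=O)O` keeps the core of compound 3 and differs as follows: sec-butyl in place of isobutyl on a saturated chain carbon bound to an amide-type nitrogen and a carbonyl carbon. This is sec-butyl in place of isobutyl on a saturated chain carbon bound to an amide-type nitrogen and a carbonyl carbon, and the two have the same atoms, joined differently.

Among the measured compounds shown here, no measured pair makes this exact exchange. The nearest evidence is a 1.5-fold lower number from compound 1 to compound 2 (0.17 log units; within the scatter), with isopropyl in place of hydrogen on a saturated chain carbon. The exchange of hydrogen for methyl on the oxygen gave a 1.2-fold lower number from compound 2 to compound 3 (0.10 log units; within the scatter), and the wider change gave a 1.9-fold lower number from compound 1 to compound 3 (0.27 log units; within the scatter). Each of these changes stayed within the scatter, and the exchange in compound 4 adds no atoms, so no clear direction can be drawn.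

In this assay, for the measured compounds named here, the expected outcome is a 1.0-fold higher number from compound 3 to compound 4 (0.02 log units; within the scatter), with no step expected beyond the scatter. The estimate for compound 4 is 18000 nM, with an expected range of 9000 nM to 36000 nM.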

Compound 4, half-maximal inhibitory concentration: 33200 nM
The estimate for compound 4 lay 1.8-fold (0.27 log units) below the measured number, within the range that was stated.
By their numbers in this assay, from the lowest: compounds 3, 2, 1 and 4 (each within the scatter of the next).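

Among the compounds shown here, exchanging isobutyl for sec-butyl on the saturated chain carbon bound to an amide-type nitrogen and a carbonyl carbon gives the first direct reading of this change in this assay as a 1.9-fold higher number from compound 3 to compound 4 (0.28 log units; within the scatter) and so shows that rejoining the same atoms, which also adds a defined stereocentre, does not take the number beyond the scatter. The other two steps also stay within the scatter, at a 1.5-fold higher number from compound 2 to compound 4 (0.19 log units; within the scatter) and a 1.0-fold higher number from compound 1 to compound 4 (0.01 log units; within the scatter) so compound 4 stands level with compound 1, compound 2 and compound 3, and this position has not yet given a separable result across isopropyl, hydrogen and sec-butyl variations. Nothing available bears on why the number for compound 4 falls where it does.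

The compounds shown leave open whether a benzyl group or a longer chain ending in an amine, placed on this same carbon, would give a step beyond the scatter. They also leave open whether a primary amide in place of the carboxylic acid would separate from compound 4, or whether the sec-butyl group with the opposite arrangement at its stereocentre would read differently.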